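Tetrazolyl for pyrazolyl on a bombesin receptor subtype-3 agonist

The source may report more compounds than this note shows. Statements on the series, on what has been measured and on what is new or still open speak of the compounds shown alone.

Measured so far:
Compound 1 `CCC(C)(C)Cc1c[nH]c(CCc2ccc(-c3ccncc3)cc2)n1`: 15 nM
Compound 2 `CCC(C)(C)Cc1c[nH]c(CCc2ccc(-n3cccn3)cc2)n1`: 9 nM

In a functional assay on HEK293 cells for agonist activity at Bombesin receptor subtype-3 (Mus musculus), read by luminescence and calcium flux, with a stated time of 10 min (on this read-out lower numbers stand for an effect already at smaller amounts and higher numbers for an effect only at larger amounts of compound), compound 2 gives the lowest of the two numbers recorded; its nearest neighbour is compound 1, and the step of a 1.7-fold lower number from compound 1 to compound 2 (0.22 log units; within the scatter) lies within the scatter, so the two cannot be ordered. Compound 3 `CCC(C)(C)Cc1c[nH]c(CCc2ccc(-n3ncnn3)cc2)n1` has not yet been measured in this assay. It differs from compound 2 in one place only: 2H-tetrazol-2-yl in place of 1H-pyrazol-1-yl on an aromatic carbon. Among the measured compounds shown here, the one measured step that bears on this change is the exchange of pyridin-4-yl for 1H-pyrazol-1-yl at the same place, a 1.7-fold lower number from compound 1 to compound 2 (0.22 log units; within the scatter), which stayed within the scatter. A second small aromatic ring of five heavy atoms entering at the same position is therefore expected to give, at most, a step of similar size, with no direction that the data can support. The number for compound 3 is estimated at 15 nM, within a range of 5 nM to 45 nM, meaning an expected step of a 1.7-fold higher number from compound 2 to compound 3 (0.22 log units; within the scatter).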

Compound 3, half-maximal effective concentration: 25 nM
For compound 3 the middle estimate is 1.7-fold (0.22 log units) below the measured one, and the stated range covers the measured number.
By their numbers in this assay, from the lowest: compounds 2, 1 and 3 (each within the scatter of the next, the first and the last beyond it).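

In this assay the exchange of 1H-pyrazol-1-yl for 2H-tetrazol-2-yl gives a 2.8-fold higher number from compound 2 to compound 3 (0.44 log units; beyond the scatter), the only step among these compounds at this aromatic carbon, para to a large group, that lies beyond the scatter. Both groups are five-membered aromatic rings with 5 heavy atoms and no net charge, so the modest step accompanies a change in the count of hetero atoms and hydrogen-bond acceptors, not in ring size. The exchange of pyridin-4-yl for 2H-tetrazol-2-yl, by contrast, gives a 1.7-fold higher number from compound 1 to compound 3 (0.22 log units; within the scatter), so these two different rings cannot be told apart here.

Nothing available explains the step from the pyrazolyl to the tetrazolyl ring. From the compounds shown here alone, it also remains open how a carboxylic acid or an amine would fare at this position.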